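Methoxy to phenoxy: from compound 3 to compound 4

The source may report more compounds than this note shows. Statements on the series, on what has been measured and on what is new or still open speak of the compounds shown alone.

Measured so far in an ADME assay on HEK293 cells (Homo sapiens) for cytotoxicity, read by luminescence, with a stated time of 72 h (on this read-out lower numbers stand for an effect already at smaller amounts and higher numbers for an effect only at larger amounts of compound), each value a limit of the assay:
- compound 1 `CCOC(=O)c1c(-c2cccc(Oc3ccccc3)c2)[nH]c2cc(OC)ccc2c1=O`: > 22000 nM
- compound 2 `CCOC(=O)c1c(-c2cccc(-c3ccccc3)c2)[nH]c2cc(OC)c(OC)cc2c1=O`: > 22000 nM
- compound 3 `CCOC(=O)c1c(-c2cccc(OC)c2)[nH]c2cc(OC)c(OC)cc2c1=O`: > 22000 nM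

Compound 3 stands at > 22000 nM, which is a limit and not a number. The same holds across the set, as the limit of > 22000 nM in this assay, at which 3 of the 3 values shown sit, shows.

The next compound is compound 4 `CCOC(=O)c1c(-c2cccc(Oc3ccccc3)c2)[nH]c2cc(OC)c(OC)cc2c1=O`, and the change is phenyl in place of methyl on an oxygen on an aromatic ring. In words, this is phenyl in place of methyl on an oxygen on an aromatic ring, or methoxy to phenoxy.

Going by the values given here, the only measured step that bears on it is a step that the two limits leave unreadable from compound 2 to compound 3, so it offers no size to carry over. No step beyond the scatter is expected in this assay for compound 4 because the limit of > 22000 nM in this assay, at which 3 of the 3 values shown sit, gives no readable direction. The expected step is a step that the limit leaves unreadable from compound 3 to compound 4, and a report of a limit alone is the likeliest outcome.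

For compound 4 the estimated value is 28000 nM, with an expected range of 10000 nM to 60000 nM.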

Compound 4, half-maximal effective concentration: > 22000 nM
Compound 4: a limit, no number; the forecaster's own chance of this, stated with the estimate: 85%; the middle value lies beyond the limit too.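

In this assay, going by these compounds alone, compound 4 gives > 22000 nM, a limit and not a number, so no step linking compound 4 to compound 1, compound 2 or compound 3 can be read. Still open is whether these compounds differ at all, and at what concentration any has an effect, with all values at one limit: the limit of > 22000 nM in this assay, at which 4 of the 4 values shown sit.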